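Working notes: the step to compound 3

The source may report more compounds than this note shows. Statements on the series, on what has been measured and on what is new or still open speak of the compounds shown alone.

compound 1 `CN1CCN(c2ccc(Nc3ncc(Cl)c(NCc4ccc(C(F)(F)F)cc4)n3)nc2)CC1` gives 19100 nM in a functional assay on MDA-MB-231 cells (Homo sapiens) for inhibition, read by CCK-8 assay, with a stated time of 48 h; a higher number here means a weaker inhibitor of growth, a lower number a stronger inhibitor of growth
compound 2 `CC(C)c1cccc(Nc2nc(Nc3ccc(N4CCN(C)CC4)cn3)ncc2Cl)c1` gives 5590 nM in this assay

Among the measured compounds shown here, compound 2 holds the lower of the two numbers in this assay, with compound 1 as its only neighbour. Compound 3 `Cc1cc(C)c(Nc2nc(Nc3ccc(N4CCN(C)CC4)cn3)ncc2Cl)c(C)c1` is not yet measured. It carries 2,4,6-trimethylphenyl in place of 3-isopropylphenyl on a nitrogen on an aromatic ring. For the measured compounds named here, the only measured change at this place is modest, a 3.4-fold lower number from compound 1 to compound 2 (0.53 log units; beyond the scatter), and it replaced 4-(trifluoromethyl)benzyl, so it bears only loosely on the new change. Going by the values given here, no measured compound carries 2,4,6-trimethylphenyl, and the data give no firm direction. A step no larger than that measured one is therefore expected in this assay. The estimated step is a 1.1-fold higher number from compound 2 to compound 3 (0.03 log units; within the scatter), with its direction uncertain. For compound 3 the expected value is 6000 nM, with an estimated range from 2000 nM to 18000 nM.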

Compound 3, concentration for 50% growth inhibition: 21000 nM
For compound 3 the middle estimate is 3.5-fold (0.54 log units) below the measured one; measured number above the stated range.
By their numbers in this assay, from the lowest: compound 2; then compounds 1 and 3 (each within the scatter of the next).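

In this assay, this place on the nitrogen separates two all-carbon aryl groups that have the same heavy-atom count and differ only in how those atoms are joined: a 3.8-fold higher number from compound 2 to compound 3 (0.57 log units; beyond the scatter). The replacement of 4-(trifluoromethyl)benzyl by 2,4,6-trimethylphenyl gives no readable difference, a 1.1-fold higher number from compound 1 to compound 3 (0.04 log units; within the scatter), so among the groups shown only 3-isopropylphenyl stands apart, with a lower number than either of the others. Nothing on hand bears on why these groups differ.

From the compounds shown here alone, whether the step follows the methyl groups of 2,4,6-trimethylphenyl or the loss of the isopropyl group stays open, and an unsubstituted phenyl group at this place would bear on that question. Going by these compounds, how an amine or a carboxylic acid on this aromatic ring would read in this assay also remains open.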